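Removing One Fluorine from a Difluorophenyl Amide

This account rests on a few compounds, and the source may have more. Where it says the series, first, only, none or still open, it means among the compounds named here.

Of the compounds shown here, three sharing one core have been tested in an assay on membranes from Cerebral cortex for displacement of a labelled ligand from Neuronal acetylcholine receptor; alpha4/beta2 (Rattus norvegicus); on this read-out higher numbers stand for weaker inhibition and lower numbers for stronger inhibition. Compound 1 `O=C(Nc1ccc(I)cc1)c1cncc(N2CC3CC(C2)N3)c1` gives 0.366 nM. Compound 2 `O=C(Nc1ccccc1F)c1cncc(N2CC3CC(C2)N3)c1` gives 0.315 nM, and the change a 1.2-fold lower number from compound 1 to compound 2 (0.07 log units; within the scatter) stays within the scatter. Compound 3 `O=C(Nc1ccc(F)cc1F)c1cncc(N2CC3CC(C2)N3)c1` gives 0.051 nM, the lowest of the three numbers: its nearest neighbour is compound 2, with a 6.2-fold lower number from compound 2 to compound 3 (0.79 log units; beyond the scatter), and the furthest is compound 1, with a 7.2-fold lower number from compound 1 to compound 3 (0.86 log units; beyond the scatter). Both of these steps lie beyond the scatter, so compound 3 stands apart as the strongest binder of the three.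

Compound 4 `O=C(Nc1ccc(F)cc1)c1cncc(N2CC3CC(C2)N3)c1` has not yet been measured. The change from compound 3 is hydrogen in place of fluoro on an aromatic carbon; the fluoro that leaves sits ortho to a large group and meta to a fluoro group, so that 2,4-difluorophenyl becomes 4-fluorophenyl. Going by the values given here, no measured step removes a fluoro from exactly this position. The closest guide is the pair compound 2 and compound 3, where putting a fluoro in place of a hydrogen gave a 6.2-fold lower number from compound 2 to compound 3 (0.79 log units; beyond the scatter); compound 1 and compound 2 show that two rings each carrying a single halogen sat within the scatter of each other. A partial step back toward those values is therefore expected, with a 2.9-fold higher number from compound 3 to compound 4 (0.47 log units; beyond the scatter). Compound 4 is estimated at 0.15 nM, with a likely range from 0.05 nM to 0.45 nM.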

Compound 4, inhibition constant: 0.01 nM
The estimate for compound 4 lay 15-fold (1.18 log units) above the measured number; measured number outside the range, below it.
By their numbers in this assay, from the lowest: compound 4; then compound 3; then compounds 2 and 1 (each within the scatter of the next).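

Taking the fluoro off the aromatic carbon ortho to a large group does not weaken binding in this assay (a 5.1-fold lower number from compound 3 to compound 4 (0.71 log units; beyond the scatter)), so the second fluoro of 2,4-difluorophenyl is not needed for the low number, and the ring with hydrogen at this place is the stronger binder of the pair. Compounds 1 and 2 had suggested that rings carrying one halogen differ little, but compound 4 shows otherwise: moving the single fluoro to give 4-fluorophenyl is a large step (a 32-fold lower number from compound 2 to compound 4 (1.50 log units; beyond the scatter)), and so is exchanging iodo for fluoro on the same ring carbon (a 37-fold lower number from compound 1 to compound 4 (1.56 log units; beyond the scatter)), which makes compound 4 the strongest binder of the four. The data offer no measurement that explains why these steps run as they do.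

The compounds shown leave open how a plain phenyl ring, with hydrogen at both of these places, would compare, so the contribution of the remaining fluoro cannot yet be sized. Also open, from the compounds shown here alone, is where chloro, bromo or methoxy on that same ring carbon would fall in the wide span between fluoro and iodo.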